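Benzyl for tert-butyl on the E-drawn ester

This account rests on a few compounds, and the source may have more. Where it says the series, first, only, none or still open, it means among the compounds named here.

Of the compounds shown here, three have been measured in an ADME assay on HEK293 cells (Homo sapiens) for inhibition, read by CellTiter-Glo, with a stated time of 96 h, tested at 100 uM; on this read-out lower numbers stand for less inhibition and higher numbers for more inhibition at the one concentration tested (going by the name of the read-out). Compound 1 `CC(C)(C)OC(=O)/C=C\NC(=O)[C@H](O)C(C)(C)CO` gives -9%. Compound 2 `CC(C)(CO)[C@@H](O)C(=O)N/C=C\C(=O)OCc1ccccc1` gives 7%. Compound 3 `CC(C)(C)OC(=O)/C=C/NC(=O)[C@H](O)C(C)(C)CO` gives -1%, which is the second highest of the three numbers, with compound 1 nearest and compound 2 furthest, both within the scatter of it. The step of a number 8 percentage points higher from compound 1 to compound 3 (within the scatter) stays within the scatter, a result consistent with the fact that compounds 1 and 3 differ only in the configuration as drawn. Going by the values given here, the step of a number 16 percentage points higher from compound 1 to compound 2 (beyond the scatter) is the one change that reaches beyond the scatter, a modest rise.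

Compound 4 `CC(C)(CO)[C@@H](O)C(=O)N/C=C/C(=O)OCc1ccccc1` has not yet been measured. It differs from compound 3 in a single place: benzyl in place of tert-butyl on an oxygen next to a carbonyl group. The measured step that bears on this is the same exchange made on the pair drawn Z, a number 16 percentage points higher from compound 1 to compound 2 (beyond the scatter). Since the E- and Z-drawn esters gave numbers within the scatter of one another in compounds 1 and 3, that same rise is expected here, giving an estimated step of a number 14 percentage points higher from compound 3 to compound 4 (beyond the scatter) in this assay. Compound 4 is therefore expected to show about 13%, with a range from -2% to 27%.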

Compound 4, a percentage reported as inhibition, at one concentration (the size of the read-out at that concentration, not a potency): 5%
Compound 4: the middle estimate sits 8 percentage points above what was measured, within the range that was stated.
By their numbers in this assay, from the lowest: compounds 1, 3, 4 and 2 (each within the scatter of the next, the first and the last beyond it).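

In this assay, benzyl in place of tert-butyl on an oxygen next to a carbonyl group gives a number 6 percentage points higher from compound 3 to compound 4 (within the scatter), so on the pair drawn E the exchange stays inside the scatter, whereas on the pair drawn Z it went beyond it. That contrast is not a firm difference between the two pairs, and the exchange can be read as similar on both: the same change on two cores in this assay, a number 16 percentage points higher (beyond the scatter) from compound 1 to compound 2 and a number 6 percentage points higher (within the scatter) from compound 3 to compound 4, 10 percentage points apart, within the scatter of two such steps The benzyl pair also gives a number 2 percentage points lower from compound 2 to compound 4 (within the scatter), so the double bond drawn E rather than Z produces no step beyond the scatter with benzyl, as was already seen with tert-butyl, and this comparison isolates the double bond: the fact that compounds 2 and 4 differ only in the configuration as drawn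

From the compounds shown here alone, it remains open whether a carboxylic acid in place of the ester, or a longer chain than benzyl on this oxygen, would give a step clearly beyond the scatter on both pairs. With a single concentration in this assay, the compounds shown also leave open how these numbers would change at other concentrations, and they give no potency.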